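Adding a Third Fluorine to the Benzyl Group of Compound 2

The source may report more compounds than this note shows. Statements on the series, on what has been measured and on what is new or still open speak of the compounds shown alone.

Measured so far:
compound 1 `COc1ccc2[nH]c3c(c2c1)CCNC31CCN(Cc2c(F)ccc(Cl)c2F)CC1` — 1500 nM
compound 2 `COc1ccc2[nH]c3c(c2c1)CCNC31CCN(Cc2cccc(F)c2F)CC1` — 13600 nM

Both compounds were tested in an assay on FRT cells for positive allosteric modulation of Cystic fibrosis transmembrane conductance regulator variant N1303K (Homo sapiens), in the presence of a further agent that is not named here; a lower number here means that less compound is needed, a higher number that more compound is needed for the effect. Compound 2 holds the highest number of the two; its nearest neighbour is compound 1, which lies a 9.1-fold higher number from compound 1 to compound 2 (0.96 log units; beyond the scatter) away from it in the opposite direction. Among the measured compounds shown here, that single step is the only change at the benzyl position seen so far, and it shows that the pattern of halogens on this aromatic ring can move the result well beyond the scatter.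

Compound 3 `COc1ccc2[nH]c3c(c2c1)CCNC31CCN(Cc2cc(F)c(F)cc2F)CC1` has not been measured. It differs from compound 2 in one place: 2,4,5-trifluorophenyl in place of 2,3-difluorophenyl on a saturated chain carbon bound to an amine nitrogen in a ring. The step from compound 1 to compound 2 bears on this change only loosely, since it exchanged a chlorine-bearing ring for a difluorophenyl rather than adding a third fluorine. With that in mind, compound 3 is expected to come out somewhat lower than compound 2, by a 2.3-fold lower number from compound 2 to compound 3 (0.36 log units; beyond the scatter), though with wide uncertainty. The estimate for compound 3 in this assay is 6000 nM, within a range from 1500 nM to 25000 nM.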

Compound 3, half-maximal effective concentration: 600 nM
Beside the measured number, compound 3's estimate is 10-fold (1.00 log units) above it; measured number outside the range, below it.
By their numbers in this assay, from the lowest: compound 3; then compound 1; then compound 2.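

The benzyl position proves more responsive than the first pair suggested: in this assay, the change to 2,4,5-trifluorophenyl gives a 23-fold lower number from compound 2 to compound 3 (1.36 log units; beyond the scatter). The same group also improves on the chlorine-bearing ring, with a 2.5-fold lower number from compound 1 to compound 3 (0.40 log units; beyond the scatter), so among these three compounds a chlorine is not needed to reach the lowest number, and fluorine alone can give it. No supporting evidence is available to explain either step.

The step from 2,3-difluorophenyl to 2,4,5-trifluorophenyl changes both the number of fluorines and their arrangement, so the compounds shown cannot separate these two contributions. As far as these compounds go, it also remains open how this position would respond to a 2,4,5-trichlorophenyl group, or to a ring carrying a nitrile or a methoxy group.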